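The source may report more compounds than this note shows. Statements on the series, on what has been measured and on what is new or still open speak of the compounds shown alone.

Measured compounds in an assay on brain for binding affinity to Neuronal acetylcholine receptor; alpha4/beta2 (Rattus norvegicus), read by radioligand binding; a higher number here means a weaker inhibitor, a lower number a stronger inhibitor:
- compound 1, `C=Cc1ccc(OC[C@@H]2CCN2)cn1`, gives 1.25 nM
- compound 2, `Clc1cncc(OC[C@@H]2CCN2)c1`, gives 0.042 nM
- compound 3, `Clc1cncc(OC[C@H]2CCN2)c1`, gives 0.12 nM

Compound 3 sits second highest of the three numbers in this assay. Its nearest neighbour is compound 2, with the step of a 2.9-fold higher number from compound 2 to compound 3 (0.46 log units; beyond the scatter); compound 1 stands furthest away, with the higher number of the three. The only cause that can be named for that step is the fact that compounds 2 and 3 differ only in the configuration as drawn.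

Compound 4, `Cc1cncc(OC[C@H]2CCN2)c1`, has not yet been measured in this assay. It differs from compound 3 by methyl in place of chloro on an aromatic carbon, two atoms from the ring nitrogen. Going by the values given here, no measured step changes this substituent, so nothing bears directly on it. Among the compounds with values here, the one step that is available, from compound 2 to compound 3, concerns configuration alone and was modest. An exchange of one substituent for another of the same size at the same place is expected to move the number by a comparably modest amount, most likely upward, giving an expected step of a 3.3-fold higher number from compound 3 to compound 4 (0.52 log units; beyond the scatter). For compound 4 the estimate in this assay is 0.4 nM, with a range from 0.1 nM to 1.5 nM.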

Compound 4, inhibition constant: 0.16 nM
For compound 4 the middle estimate is 2.5-fold (0.40 log units) above the measured one; the range from low to high includes it.
By their numbers in this assay, from the lowest: compound 2; then compounds 3 and 4 (each within the scatter of the next); then compound 1.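

In this assay, methyl in place of chloro on an aromatic carbon, two atoms from the ring nitrogen, gives a 1.3-fold higher number from compound 3 to compound 4 (0.12 log units; within the scatter). Going by these compounds alone, this is the first reading of a change at this position, since the only earlier step, a 2.9-fold higher number from compound 2 to compound 3 (0.46 log units; beyond the scatter), concerned configuration alone and lay beyond the scatter; in this configuration, the two substituents, each of one heavy atom and with no hydrogen-bond donors or acceptors, cannot be told apart in this assay. Nothing available bears on why this exchange leaves the reading within the scatter.

Still open, going by these compounds, is whether the position tolerates anything other than these two small groups, such as a methoxy group, a nitrile, an amine or a longer chain, since one exchange between groups of one heavy atom says nothing about larger or hydrogen-bonding substituents. Also open is whether methyl and chloro would read alike on the opposite configuration, that of compound 2, as the series shown holds the methyl group in one configuration only.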